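Methoxy to Nitro, Applied a Second Time

The source may hold more compounds than are shown below. What is called first, only, known or untested is meant among the compounds shown, and "the series" means these compounds.

Compound 1 `C#CCOc1ccc(/C=C/C(=O)c2ccc(OC)cc2)cc1` and compound 2 `C#CCOc1ccc(/C=C/C(=O)c2ccc([N+](=O)[O-])cc2)cc1` share one core, while compound 3 `COc1ccc(C(=O)/C=C/c2ccc(OCc3cn(Cc4ccccc4)nn3)cc2)cc1` is built on another; the difference between the two cores is not broken down here. In a functional assay on HepG2 cells (Homo sapiens) for inhibition, read by MTT assay, with a stated time of 48 h, tested at 10 uM (a lower number here means less inhibition of growth, a higher number more inhibition of growth at the concentration tested), compound 1 gives 25%, compound 2 gives 27%, and compound 3 gives 51%. The change nitro in place of methoxy on an aromatic carbon produced a number 2 percentage points higher from compound 1 to compound 2 (within the scatter). Compound 4 `O=C(/C=C/c1ccc(OCc2cn(Cc3ccccc3)nn2)cc1)c1ccc([N+](=O)[O-])cc1` arises from compound 3 by nitro in place of methoxy on an aromatic carbon, the same change at a place described in the same words. Because a number 2 percentage points higher from compound 1 to compound 2 (within the scatter) lies within the scatter, the expected step is a number 1 percentage points lower from compound 3 to compound 4 (within the scatter). Compound 4 is therefore estimated at 50%, with a range expected from 38% to 62%.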

Compound 4, percent growth inhibition at one concentration: "not active" (no number reported)
Compound 4: no number reported; the estimate stays without a comparison.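

Among these compounds, compound 4 is reported only as not active, without a number, and no step from compound 3 to compound 4 can be read. The compounds shown leave open how far compound 4 lies from compound 3 in growth inhibition. No data shown here bear on this result.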